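Moving the methyl group within a series of inactive hydrazides

The source may report more compounds than this note shows. Statements on the series, on what has been measured and on what is new or still open speak of the compounds shown alone.

Of the compounds shown here, three have been tested in a functional assay on OVCAR-3 cells (Homo sapiens) for antiproliferative activity, read by MTT assay, with a stated time of 24 h (a lower number here means a stronger inhibitor, a higher number a weaker inhibitor), and a fourth, built on the same pattern, has not. Compound 1 `Cc1ccccc1C(=O)NNC(=O)c1ccc(NS(=O)(=O)c2cnc(O)nc2O)cc1` carries a 2-methylphenyl group on a carbonyl carbon whose other neighbour is an amide-type nitrogen. In this assay compound 1 reaches only the limit of the measurement, > 20000 nM. Compound 2 `Cc1ccc(C(=O)NNC(=O)c2ccc(NS(=O)(=O)c3cnc(O)nc3O)cc2)cc1` differs from compound 1 by 4-methylphenyl in place of 2-methylphenyl on a carbonyl carbon, and in this assay compound 2 likewise gives only the limit, > 20000 nM. The step between them, a step that the two limits leave unreadable from compound 1 to compound 2, therefore cannot be read. Compound 3 `Cc1ccccc1C(=O)NNC(=O)c1ccccc1NS(=O)(=O)c1cnc(O)nc1O` has a core that differs from that of compound 1, and the difference between the two cores is not broken down here. In this assay compound 3 also stops at the limit, > 20000 nM. All three sit at one place, (the limit of > 20000 nM in this assay, at which 3 of the 3 values shown sit).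

Compound 4 `Cc1ccc(C(=O)NNC(=O)c2ccccc2NS(=O)(=O)c2cnc(O)nc2O)cc1` is the unmeasured member; it differs from compound 3 by 4-methylphenyl in place of 2-methylphenyl on a carbonyl carbon, the same change seen from compound 1 to compound 2. Since that earlier change left both ends at the limit, compound 4 is expected to stay there too, with a step that the limit leaves unreadable from compound 3 to compound 4 from compound 3. The estimate for compound 4 in this assay is 30000 nM, ranging from 15000 nM to 80000 nM.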

Compound 4, half-maximal inhibitory concentration: 12900 nM
The estimate for compound 4 lay 2.3-fold (0.37 log units) above the measured number; the whole stated range lies above it.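

On the core of compound 3, putting 4-methylphenyl in place of 2-methylphenyl on a carbonyl carbon gives, in this assay, an at least 1.5-fold lower number from compound 3 to compound 4 (0.19 log units; that floor lies within the scatter), and since compound 3 has only a limit, this is a floor that does not by itself establish a real gain, though the true step could be larger. The same change on the core of compound 1 cannot be read, since both of its ends are limits, so the data cannot say whether the change acts alike on the two cores. Compound 1, compound 2 and compound 3 each give a limit and not a number: the limit of > 20000 nM in this assay, at which 3 of the 4 values shown sit.

Among these compounds, compound 4, at 12900 nM, is thus the only compound here with a true number, and a single number cannot show a trend. On these data alone, it remains open what an ethyl group, an amine or a carboxylic acid in place of the methyl would do on either core.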